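The source may report more compounds than this note shows. Statements on the series, on what has been measured and on what is new or still open speak of the compounds shown alone.

Measured so far in a functional assay on HT-29 cells (Homo sapiens) for cytotoxicity, read by MTT assay, with a stated time of 6 days; a higher number here means that more compound is needed for the effect, a lower number that less compound is needed:
- compound 1 `COC(=O)c1c(-c2ccc([N+](=O)[O-])cc2)oc2cc(OC)ccc2c1=O`: > 25 ug/mL
- compound 2 `O=C(O)c1c(-c2ccc([N+](=O)[O-])cc2)oc2ccccc2c1=O`: > 25 ug/mL

Compound 2 gives > 25 ug/mL, which is a limit and not a number. Compound 1 gives > 25 ug/mL, also a limit. For the measured compounds named here, the series therefore stands at the limit of > 25 ug/mL in this assay, at which 2 of the 2 values shown sit, and no measured step is available to size the next change.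

Compound 3 `COc1ccc2c(=O)c(C(=O)O)c(-c3ccc([N+](=O)[O-])cc3)oc2c1` follows from compound 2 by one change: methoxy in place of hydrogen on an aromatic carbon. Compound 1 also carries a methoxy, and its reading of > 25 ug/mL is a limit too. No step beyond the scatter is expected in this assay, and a further limit is the likeliest report. The estimated step is small, a step that the limit leaves unreadable from compound 2 to compound 3. For compound 3 the expected value is 30 ug/mL, with an estimated range of 15 ug/mL to 60 ug/mL.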

Compound 3, concentration for half-maximal effect: > 25 ug/mL
Compound 3 was reported as a limit; the forecaster's own chance of this, stated with the estimate: 80%; the middle value is on the limit's open side.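

Compound 3 gives > 25 ug/mL in this assay, which is a limit. The steps from compound 1 and from compound 2 to compound 3 therefore cannot be read. The series stands as before: the limit of > 25 ug/mL in this assay, at which 3 of the 3 values shown sit.

The compounds shown leave open what actual value any of the three has in this assay, and whether any change to the shared core gives a readable one.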